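Propoxy in Place of Benzylamino on a Purine-Like Core

The source may hold more compounds than are shown below. What is called first, only, known or untested is meant among the compounds shown, and "the series" means these compounds.

This account follows the step from compound 2 to compound 4 in an ADME assay on Akata cells (Homo sapiens) for cytotoxicity, with a stated time of 7 days; on this read-out higher numbers stand for lower toxicity in this test and lower numbers for higher toxicity in this test. Compound 2 has the structure `Nc1nc(NCc2ccccc2)c2ncn(/C=C3/CC3(CO)CO)c2n1`; in this assay compound 2 reaches only the limit of > 24000 nM, a limit of the measurement and not a number. Compound 1, `C=CCOc1nc(N)nc2c1ncn2/C=C1/CC1(CO)CO`, carries allyloxy where compound 2 carries benzylamino; compound 1 likewise gives only the limit > 20000 nM. Compound 3, `Nc1nc2c(ncn2/C=C2/CC2(CO)CO)c(=O)[nH]1`, also gives only the limit > 20000 nM. For the measured compounds named here, the one measured step that bears on the change, a step that the two limits leave unreadable from compound 1 to compound 2, cannot be read, since both of its ends sit at a limit.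

Compound 4, `CCCOc1nc(N)nc2c1ncn2/C=C1/CC1(CO)CO`, differs from compound 2 by propoxy in place of benzylamino on an aromatic carbon. Going by the values given here, no readable step is available for this kind of change; the only evidence is the limit of > 20000 nM in this assay, at which 2 of the 3 values shown sit, and (the limit of > 24000 nM in this assay, at which 1 of the 3 values shown sits), where all three measured compounds sit. Compound 4 is therefore expected to sit at or beyond the same limit, with no step beyond the scatter. The expected step is a step that the limit leaves unreadable from compound 2 to compound 4, understood as unreadable against the limit. Compound 4 is estimated at 30000 nM, within a range from 15000 nM to 80000 nM.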

Compound 4, half-maximal cytotoxic concentration: > 20000 nM
Compound 4: no number, only a limit; the forecaster's own chance of this, stated with the estimate: 85%; the middle value is on the limit's open side.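

In this assay compound 4 gives > 20000 nM, which is a limit and not a number. For the compounds shown here, its steps from compound 1 and from compound 2 cannot be read, so no new step comes from this result. The compounds shown leave open how compound 1, compound 2 and compound 4 truly differ in this assay, as none has a readable number.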